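This account rests on a few compounds, and the source may have more. Where it says the series, first, only, none or still open, it means among the compounds named here.

Measured in a functional assay on DU-145 cells (Homo sapiens) for cytotoxicity, read by MTT assay, with a stated time of 72 h; on this read-out higher numbers stand for weaker inhibition and lower numbers for stronger inhibition:
- Compound 1 `O=c1ccc2nc(-c3ccccc3)nn(-c3ccccc3)c-2c1`: 230 nM
- Compound 2 `Nc1cc2nc(-c3ccccc3)nn(-c3ccccc3)c-2cc1=O`: 1830 nM

Compound 2 has the higher of the two numbers, at 1830 nM, so it is the weaker inhibitor of the pair. The next compound, compound 3 `CNc1cc2nc(-c3ccccc3)nn(-c3ccccc3)c-2cc1=O`, differs from it by methyl in place of hydrogen on a nitrogen on an aromatic ring, or amino to methylamino.

Within the data shown here, only one measured step bears on this change: an 8.0-fold higher number from compound 1 to compound 2 (0.90 log units; beyond the scatter). That step installed the amino group, and its size is modest but beyond the scatter. Among the measured compounds shown here, it does not show what a methyl on that nitrogen does, and no measured pair covers such a change. The added group is small and the amino nitrogen remains in place, so compound 3 is expected to stay close to compound 2 in this assay, with no step beyond the scatter in either direction. The expected change is a 1.1-fold lower number from compound 2 to compound 3 (0.06 log units; within the scatter). The estimate for compound 3 is 1600 nM, with an expected range of 550 nM to 4500 nM.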

Compound 3, half-maximal inhibitory concentration: 980 nM
Estimate against measurement, compound 3: 1.6-fold (0.21 log units) above, within the range that was stated.
By their numbers in this assay, from the lowest: compound 1; then compounds 3 and 2 (each within the scatter of the next).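

In this assay, methyl on the nitrogen on the aromatic ring gives a 1.9-fold lower number from compound 2 to compound 3 (0.27 log units; within the scatter), so this change does not separate compound 3 from compound 2, and the amino nitrogen tolerates this single added carbon without a step that can be read as a gain or a loss. Against the unsubstituted parent, the methylamino group still gives a 4.3-fold higher number from compound 1 to compound 3 (0.63 log units; beyond the scatter), so the higher number seen with the amino group in compound 2 also holds with the methylamino group in compound 3, and neither compound goes against this pattern among the three compounds shown. No measurement on these compounds bears on the cause of either step.

From the compounds shown here alone, whether the nitrogen keeps this tolerance with an ethyl group, a longer chain, a second methyl as in dimethylamino, or an acetyl group remains open. Also open, going by these compounds, is whether a hydroxyl or methoxy group on the same aromatic carbon would give a number nearer to that of compound 1 or to those of compound 2 and compound 3.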